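This account rests on a few compounds, and the source may have more. Where it says the series, first, only, none or still open, it means among the compounds named here.

Compound 1 `CC1=C(C(=O)Nc2ccc([N+](=O)[O-])cc2)C(c2ccc(Br)cc2)N=C(SCc2cccc(Cl)c2)N1`: in a functional assay on the whole organism (artery, strain albino) with Rattus norvegicus as the target, with a stated time of 240 min, at a dose of 10 mg/kg by the oral route (on this read-out lower numbers stand for less inhibition and higher numbers for more inhibition at the one dose given (going by the name of the read-out)), compound 1 gives 11.8%.
Compound 2 `CC1=C(C(=O)Nc2ccc([N+](=O)[O-])cc2)C(c2ccc(Br)cc2)N=C(SCc2ccc(F)cc2)N1`: in this assay compound 2 gives 27.2%.

Among the two measured compounds, compound 2 stands highest; its nearest neighbour is compound 1, and the only measured step, a number 15.4 percentage points higher from compound 1 to compound 2 (beyond the scatter), lies beyond the scatter. Compound 3 `CC1=C(C(=O)Nc2ccc([N+](=O)[O-])cc2)C(c2cccc([N+](=O)[O-])c2)N=C(SCc2ccc(F)cc2)N1` has not yet been measured. It differs from compound 2 in one place: 3-nitrophenyl in place of 4-bromophenyl on a saturated ring carbon. Among the measured compounds shown here, the single measured step concerns another position, the saturated chain carbon bound to a sulfur, so no measured step bears directly on the change at the saturated ring carbon. For the measured compounds named here, the size of a number 15.4 percentage points higher from compound 1 to compound 2 (beyond the scatter) shows only that swapping one aryl group elsewhere in the shared core can move the read-out in this assay by a modest amount. Going by the values given here, with no direct precedent, the estimate for compound 3 rests on compound 2 alone and carries a wide range. The expected step is a number 0.2 percentage points lower from compound 2 to compound 3 (within the scatter), nothing beyond the scatter in either direction. Compound 3 is therefore estimated at 27% in this assay, with a range from 5% to 50%.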

Compound 3, a percentage reported as inhibition, in the whole organism at one dose (the size of the read-out at that dose, not a potency): 22.6%
Beside the measured number, compound 3's estimate is 4.4 percentage points above it, within the range that was stated.
By their numbers in this assay, from the lowest: compound 1; then compounds 3 and 2 (each within the scatter of the next).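

The exchange of 4-bromophenyl for 3-nitrophenyl on the saturated ring carbon, the first change measured at this position, gives a number 4.6 percentage points lower from compound 2 to compound 3 (within the scatter) in this assay at the one oral dose. Among the compounds shown here, the entering group has 9 heavy atoms, 2 hydrogen-bond acceptors and 1 double bond outside aromatic rings, against 7 heavy atoms and no acceptors in the leaving group, and with these differences the read-out still stays within the scatter, whereas the one step measured at the saturated chain carbon bound to a sulfur, a number 15.4 percentage points higher from compound 1 to compound 2 (beyond the scatter) and lies beyond it. Nothing shown here offers an explanation for this result.

This single pair cannot separate the change of substituent from the change of its place on the phenyl ring, so 4-nitrophenyl and 3-bromophenyl on the same carbon would be needed to tell the two apart. From the compounds shown here alone, whether the position stays this flat for other groups also remains open, for instance a phenyl ring carrying an amine or a carboxylic acid, or a saturated alkyl chain in place of the aryl group.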